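Compound 3 to compound 4: a methoxy-bearing ring returns

The compounds below may be only part of what the source reports. "The series", "measured", "known", "first", "only" and "open" are said of these compounds alone.

Values measured so far in an ADME assay (liver) for metabolic stability, with Liver microsome (Homo sapiens) as the target, read by LC-MS, using microsomes, with a stated time of 30 min, tested at 4 uM; a higher number here means that more of the compound is left, a lower number that less of the compound is left
- compound 1 `Cc1nc(N2CCN(C)CC2)c2nc(-c3ccccc3Cl)n(CCN3CCCC3=O)c2n1` gives 13%
- compound 2 `COc1cccc(-c2nc3c(N4CCN(C)CC4)nc(C)nc3n2C2CCOCC2)c1` gives 40%
- compound 3 `Cc1nc(N2CCN(C)CC2)c2nc(-c3ccccc3C#N)n(C3CCOCC3)c2n1` gives 20%

In this assay compound 3 at 20% cannot be told apart from compound 1, and it lies clearly under compound 2 at 40% in the same test. The next compound is compound 4 `COc1ccc(-c2nc3c(N4CCN(C)CC4)nc(C)nc3n2C2CCOCC2)c(C)c1` and it has 4-methoxy-2-methylphenyl in place of 2-cyanophenyl on an aromatic carbon, a swap summed up as 4-methoxy-2-methylphenyl in place of 2-cyanophenyl on an aromatic carbon in counted terms.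

Going by the values given here, one measured step bears on this directly. It is a number 20 percentage points lower from compound 2 to compound 3 (beyond the scatter) for 2-cyanophenyl in place of 3-methoxyphenyl. Among the compounds with values here, compound 4 gives up the same 2-cyanophenyl and regains a methoxy group, but the group's position differs from compound 2, and no measured compound shows what the added methyl does. So only part of that step is expected to be undone, and upward: the estimated change is a number 10 percentage points higher from compound 3 to compound 4 (within the scatter) in this assay for now. The estimated value for compound 4 is 30% (range 14% to 50%).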

Compound 4, percent of the compound remaining: 21%
Compound 4: the middle estimate sits 9 percentage points above what was measured, and the stated range covers the measured number.
By their numbers in this assay, from the lowest: compounds 1, 3 and 4 (each within the scatter of the next); then compound 2.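

In this assay, the step of a number 1 percentage points higher from compound 3 to compound 4 (within the scatter) shows that exchanging 2-cyanophenyl for 4-methoxy-2-methylphenyl on this aromatic carbon gives no readable change, even though the two groups differ in what they carry. Going by these compounds alone, the step of a number 19 percentage points lower from compound 2 to compound 4 (beyond the scatter) adds something the earlier compounds could not show: a methoxy group on the phenyl ring does not by itself go with the higher number of compound 2, since 3-methoxyphenyl and 4-methoxy-2-methylphenyl give clearly different results. No evidence is available to explain either step.

The compounds shown cannot separate the part played by the methoxy group's place on the ring from that of the added methyl. They also leave open how compound 2 would compare with an analogue carrying a dimethylamino group or a carboxylic acid on the phenyl ring in place of the methoxy group.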